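The source may report more compounds than this note shows. Statements on the series, on what has been measured and on what is new or still open speak of the compounds shown alone.

Measured in a functional assay on SF-539 cells (Homo sapiens) for cytotoxicity, read by sulforhodamine B assay, with a stated time of 48 h, tested at 0.01 uM; a higher number here means a weaker effect of the compound at the concentration tested, a lower number a stronger effect:

compound 1 `COc1ccc(-c2cc(/C=C/C(=O)c3ccc(N)cc3)[nH]n2)cc1` — 98%
compound 2 `COc1ccc(C(=O)/C=C/c2cc(-c3cc(OC)c(OC)c(OC)c3)n[nH]2)cc1OC` — 97%
compound 3 `COc1ccc(-c2cc(/C=C/C(=O)c3ccc(N)cc3)[nH]n2)cc1OC` — 93%

All three numbers lie within the scatter of one another, so no order among them is claimed. Compound 3 differs from compound 1 by methoxy in place of hydrogen on an aromatic carbon, and this gave a number 5 percentage points lower from compound 1 to compound 3 (within the scatter). The difference between the core of compound 1 and the core of compound 2 is not broken down here.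

Compound 4 `COc1cc(C(=O)/C=C/c2cc(-c3cc(OC)c(OC)c(OC)c3)n[nH]2)cc(OC)c1OC` differs from compound 2 by methoxy in place of hydrogen on an aromatic carbon. The surroundings are not identical: in compound 4 the place is also meta to a methoxy group, so this is the same kind of change rather than the same one. Since the earlier step was a number 5 percentage points lower from compound 1 to compound 3 (within the scatter), a step of a number 3 percentage points lower from compound 2 to compound 4 (within the scatter) is expected here, within the scatter. Compound 4 is therefore estimated at 94%, between 85% and 100%.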

Compound 4, a percentage reported as activity, at one concentration (the size of the read-out at that concentration, not a potency): 92%
Beside the measured number, compound 4's estimate is 2 percentage points above it, within the range that was stated.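

In this assay, methoxy in place of hydrogen on an aromatic carbon gives a number 5 percentage points lower from compound 2 to compound 4 (within the scatter), and the step carries from one core to the other with no difference between the two: the same change on two cores in this assay, a number 5 percentage points lower (within the scatter) from compound 1 to compound 3 and a number 5 percentage points lower (within the scatter) from compound 2 to compound 4, 0 percentage points apart, within the scatter of two such steps. Within the data shown here, both steps lie within the scatter, so the agreement shows only that this change leaves the read-out unmoved on both cores at the one concentration tested, not that methoxy lowers the number. It gives no potency and does not show how the change behaves on any other core.

Open, on these data alone, is whether a carboxylic acid, a fluorine or a longer chain such as ethoxy at this place would move the read-out beyond the scatter. Also open, as far as these compounds go, is whether the methoxy step would stay this small at another concentration.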